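The source may hold more compounds than are shown below. What is called first, only, known or untested is meant among the compounds shown, and "the series" means these compounds.

In a functional assay on cells (B-cell) for antiproliferative activity (on this read-out higher numbers stand for weaker inhibition and lower numbers for stronger inhibition), compound 1 `C=CC(=O)Nc1cccc(Nc2nc(Nc3ccc(OCCOC)cc3)ncc2[S+](C)[O-])c1` gives 5.85 nM. Compound 2 `C=CC(=O)Nc1cccc(-n2c(=O)n(C)c3cnc(Nc4ccc(OCCOC)cc4)nc32)c1` gives 6.84 nM. Within the data shown here, these two numbers lie within the scatter of each other, so compound 1 cannot be separated from the only other measured compound, and both sit in the low nanomolar range.

The unmeasured compound 3 `C=CC(=O)Nc1cccc(Nc2nc(Nc3ccc(N(C)C)nc3)ncc2[S+](C)[O-])c1` keeps the rest of compound 1 and changes one group: 6-(dimethylamino)pyridin-3-yl in place of 4-(2-methoxyethoxy)phenyl on a nitrogen on an aromatic ring. Among the measured compounds shown here, compound 2 carries the same 4-(2-methoxyethoxy)phenyl group as compound 1, so no measured pair shows what replacing it does, and the data give no direct size for this step.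

With so little to go on, a modest move toward weaker inhibition is expected in this assay, possibly no larger than the scatter, and the estimated step is a 1.7-fold higher number from compound 1 to compound 3 (0.23 log units; within the scatter). The expected value for compound 3 is 10 nM, with an estimated range of 3 nM to 40 nM.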

Compound 3, half-maximal inhibitory concentration: 14.9 nM
For compound 3 the middle estimate is 1.5-fold (0.17 log units) below the measured one; the measured number falls inside the stated range.
By their numbers in this assay, from the lowest: compounds 1 and 2 (each within the scatter of the next); then compound 3.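

The position on a nitrogen on an aromatic ring, whose other neighbours are aromatic carbon, now has its first measured replacement: in this assay, 6-(dimethylamino)pyridin-3-yl in place of 4-(2-methoxyethoxy)phenyl gives a 2.5-fold higher number from compound 1 to compound 3 (0.41 log units; beyond the scatter). The group at this position therefore affects the read-out, although this exchange weakens inhibition without abolishing it. No independent measurement bears on why the step occurs.

This single exchange changes the ring and its substituent together, so it leaves open how much of the step belongs to the ring nitrogen, to the dimethylamino group, or to the loss of the 2-methoxyethoxy chain; a 2-methoxyethoxy chain or a morpholine on the pyridin-3-yl ring would help to separate these parts. It also leaves open whether 6-(dimethylamino)pyridin-3-yl has a similar effect on the core of compound 2, where the same 4-(2-methoxyethoxy)phenyl group is the only version shown.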